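The compounds below may be only part of what the source reports. "The series", "measured", "known", "first", "only" and "open" are said of these compounds alone.

Measured compounds:
- compound 1 `Oc1cccc(-c2cc(-c3ccccc3O)cc(-c3ccccc3O)n2)c1` gives 5760 nM in a functional assay on T47D cells (Homo sapiens) for cytotoxicity, read by CCK-8 assay, with a stated time of 4 days; on this read-out lower numbers stand for stronger inhibition and higher numbers for weaker inhibition
- compound 2 `Oc1ccc(-c2cc(-c3ccc(O)cc3)nc(-c3cccc(O)c3)c2)cc1` gives 4470 nM in this assay

Of these two numbers compound 2 has the lower one, though compound 1 sits within the usual scatter of it, so the two are not told apart. Compound 3 `Oc1ccc(-c2cc(-c3cccc(O)c3)nc(-c3ccccc3O)c2)cc1` is not yet measured; it differs from compound 2 by 2-hydroxyphenyl in place of 4-hydroxyphenyl on an aromatic carbon on the shared core, at the carbon next to the ring nitrogen. For the measured compounds named here, with no measured step of this kind to lean on, only a small shift is expected, in no fixed direction beyond the scatter, and compound 3 is estimated at 5000 nM, between 2000 nM and 12000 nM, giving an expected step of a 1.1-fold higher number from compound 2 to compound 3 (0.05 log units; within the scatter).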

Compound 3, half-maximal inhibitory concentration: 4810 nM
Estimate against measurement, compound 3: 1.0-fold (0.02 log units) above; measured number inside the range.
By their numbers in this assay, from the lowest: compounds 2, 3 and 1 (each within the scatter of the next).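

In this assay, placing 2-hydroxyphenyl instead of 4-hydroxyphenyl on the aromatic carbon next to the ring nitrogen gives a 1.1-fold higher number from compound 2 to compound 3 (0.03 log units; within the scatter) and stays within the scatter, so this position does not separate the two groups. The exchange of 4-hydroxyphenyl for 2-hydroxyphenyl on an aromatic carbon gives a 1.2-fold lower number from compound 1 to compound 3 (0.08 log units; within the scatter) and is also within the scatter, so all three compounds remain unresolved. On these data alone, whether an amine, a carboxylic acid or a methoxy group at this position would shift the number beyond the scatter stays open. Nothing available explains why these compounds read alike.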